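This account rests on a few compounds, and the source may have more. Where it says the series, first, only, none or still open, it means among the compounds named here.

Compound 1, `COC(=O)c1ccc(NCc2cncn2Cc2cccc(C)c2)cc1-c1ccccc1`, gives > 10000 nM in a toxicity assay on NIH3T3 cells (Mus musculus) for cytotoxicity, read by resazurin assay (on this read-out higher numbers stand for an effect only at larger amounts of compound and lower numbers for an effect already at smaller amounts), and this value is a limit of the assay rather than a number.
Compound 2, `Nc1cc(-c2ccccc2)ccc1Cn1cncc1CNc1ccc(-c2cncs2)c(-c2ccccc2)c1`, gives > 1000 nM in this assay, again a limit.
Compound 3, `c1ccc(Cn2cncc2CNc2cccc(-c3ccccc3)c2)cc1`, gives > 750 nM in this assay, also a limit.

So none of the three measured compounds has a number in this assay; each sits at a limit, and the limits themselves differ, as seen in the limit of > 10000 nM in this assay, at which 1 of the 3 values shown sits, for compound 1, the limit of > 1000 nM in this assay, at which 1 of the 3 values shown sits, for compound 2 and the limit of > 750 nM in this assay, at which 1 of the 3 values shown sits, for compound 3. Compound 1 therefore cannot be placed above or below the other two; all that is known is that its effect was not seen up to its limit.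

Compound 4, `COC(=O)c1ccc(NCc2cncn2Cc2ccccc2N)cc1-c1ccccc1`, has not been measured in this assay. It differs from compound 1 in one place: 2-aminophenyl in place of 3-methylphenyl on a saturated chain carbon bound to an aromatic nitrogen. Going by the values given here, with no measured step between any pair of compounds and only limits to go by, no step beyond the usual scatter is expected in either direction. Compound 4 is thus expected to give 10000 nM in this assay, within 3000 nM to 30000 nM. The step that this estimate means, a number no higher from compound 1 to compound 4 (the limit leaves the size open), is expected to be no more than the scatter, and a limit rather than a number is again the likeliest outcome.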

Compound 4, half-maximal effective concentration: 25000 nM
For compound 4 the middle estimate is 2.5-fold (0.40 log units) below the measured one; low and high end bracket the measured number.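

No step can be read between compound 1 and compound 4 in this assay, because compound 1 stands at a limit rather than a number: the limit of > 10000 nM in this assay, at which 1 of the 4 values shown sits.

The compounds shown leave open whether 2-aminophenyl in place of 3-methylphenyl on a saturated chain carbon bound to an aromatic nitrogen changes the concentration needed for an effect in this assay, and by how much.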